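From formyl to 2-carboxyethenyl on the shared core

This account rests on a few compounds, and the source may have more. Where it says the series, first, only, none or still open, it means among the compounds named here.

- Compound 1 `C=C[C@@](C)(/C=C/c1ccc(O)cc1)CC/C=C(\C)CO`: > 36600 nM
- Compound 2 `C=C[C@@](C)(/C=C/c1ccc(O)c(C=O)c1)CCC=C(C)C`: > 36600 nM
- Compound 3 `C=C[C@@](C)(/C=C/c1ccc(O)c(/C=C/C(=O)O)c1)CCC=C(C)C`: not yet measured

In an ADME assay on HEK293 cells (Homo sapiens) for cytotoxicity, with a stated time of 72 h (a lower number here means that less compound is needed, a higher number that more compound is needed for the effect), compound 1 gives > 36600 nM, which is a limit and not a number. In this assay compound 2 likewise gives > 36600 nM, also only a limit. Compound 3 carries 2-carboxyethenyl in place of formyl on an aromatic carbon, ortho to a hydroxy group (2-carboxyethenyl in place of formyl on an aromatic carbon). No change beyond the scatter is expected in this assay, so no direction is predicted. The expected step, a step that the limit leaves unreadable from compound 2 to compound 3, stays within that scatter. For compound 3 the estimate is 40000 nM, with an expected range of 20000 nM to 80000 nM, and a further limit is the likeliest report.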

Compound 3, half-maximal effective concentration: > 36600 nM
Compound 3: only a limit was reported; the forecaster's own chance of this, stated with the estimate: 85%; the middle value is on the limit's open side.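

In this assay compound 3 gives > 36600 nM, which is a limit and not a number. Compound 2 is also reported only as a limit, so the step between compound 2 and compound 3 cannot be read. The compounds shown leave open whether 2-carboxyethenyl in place of formyl makes any difference in this assay.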